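The source may hold more compounds than are shown below. What is called first, only, known or untested is meant among the compounds shown, and "the series" means these compounds.

In a functional assay on Bel-7402 cells (Homo sapiens) for cytotoxicity, read by MTT assay (a higher number here means a weaker inhibitor, a lower number a stronger inhibitor), compound 1 `Cc1nc(Nc2ccc(Cl)c(Cl)c2)sc1C(=O)/C=C/c1ccccc1` gives 21500 nM. Compound 2 `Cc1ccc(Nc2nc(C)c(C(=O)/C=C/c3ccc(Cl)cc3)s2)cc1` reaches only a limit of this assay, > 25000 nM. One of the two values shown thus sits at the limit of > 25000 nM in this assay, at which 1 of the 2 values shown sits. Compound 3 `Cc1nc(Nc2ccc(Cl)c(Cl)c2)sc1C(=O)/C=C/c1ccc(Cl)cc1` has not yet been measured in this assay. The change from compound 2 to compound 3 is 3,4-dichlorophenyl in place of 4-methylphenyl on a nitrogen on an aromatic ring. Within the data shown here, with compound 2 known only as a limit, no step between measured compounds can be sized. The expected step of an at least 1.2-fold lower number from compound 2 to compound 3 (0.09 log units; that floor lies within the scatter) is small, with no clear direction beyond the scatter. Compound 3 is estimated at 20000 nM, within 8000 nM to 50000 nM.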

Compound 3, half-maximal inhibitory concentration: > 25000 nM
Compound 3 was reported as a limit; the forecaster's own chance of this, stated with the estimate: 45%; at least 1.2-fold (0.09 log units) between middle value and limit.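

In this assay, 3,4-dichlorophenyl in place of 4-methylphenyl on a nitrogen on an aromatic ring leaves compound 3 at a limit, as compound 2 was, so the step between them cannot be read. Chloro in place of hydrogen on an aromatic carbon gives an at least 1.1-fold higher number from compound 1 to compound 3 (0.06 log units; that floor lies within the scatter), so this change shows no effect beyond the scatter. Only compound 1 now has a readable value: the limit of > 25000 nM in this assay, at which 2 of the 3 values shown sit.

On these data alone, how far compound 3 lies from compound 1 stays open. So does whether a carboxylic acid or an amine on the phenyl ring would give a readable value in this assay.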